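Nitro Substitution on the Fused Ring of Compound 1

This account rests on a few compounds, and the source may have more. Where it says the series, first, only, none or still open, it means among the compounds named here.

compound 1, `O=S(=O)(c1ccc(-c2cnc(C3CC3)o2)cc1)N1CCc2ccccc21`: 62 nM
compound 2, `CC1Cc2ccccc2N1S(=O)(=O)c1ccc(-c2cnc(C3CC3)o2)cc1`: 20500 nM

In a functional assay on PC-3 cells (Homo sapiens) for inhibition, read by MTT assay (on this read-out higher numbers stand for weaker inhibition and lower numbers for stronger inhibition), compound 1 gives 62 nM, the lowest of the two numbers shown. Compound 2 gives 20500 nM; the step of a 330-fold higher number from compound 1 to compound 2 (2.52 log units; beyond the scatter) came with a methyl in place of hydrogen on a saturated ring carbon. Compound 3, `O=[N+]([O-])c1ccc2c(c1)CCN2S(=O)(=O)c1ccc(-c2cnc(C3CC3)o2)cc1`, has not yet been measured. Its change from compound 1 is nitro in place of hydrogen on an aromatic carbon. Among the measured compounds shown here, no measured step alters an aromatic carbon of the fused system, so the step from compound 1 to compound 2 bears only loosely on it. Compound 3 is therefore expected to stay near compound 1, with a step of a 1.6-fold higher number from compound 1 to compound 3 (0.21 log units; within the scatter) that is not clearly beyond the scatter. Compound 3 is estimated at 100 nM, within 15 nM to 800 nM.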

Compound 3, half-maximal inhibitory concentration: 1920 nM
The estimate for compound 3 lay 19-fold (1.28 log units) below the measured number; the measured number lies above the stated range.
By their numbers in this assay, from the lowest: compound 1; then compound 3; then compound 2.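

In this assay, nitro in place of hydrogen on this aromatic carbon brings a 31-fold higher number from compound 1 to compound 3 (1.49 log units; beyond the scatter), so the aromatic part of the fused system is also sensitive to substitution, not only the saturated ring carbon changed in compound 2. Nothing available explains why the number rises with nitro. The compounds shown leave open whether the loss belongs to nitro itself or to any group on this carbon. A fluorine atom or an amine here, or nitro on another aromatic carbon of the ring, could separate these readings.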